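This account rests on a few compounds, and the source may have more. Where it says the series, first, only, none or still open, it means among the compounds named here.

Measured so far:
Compound 1 `CS(=O)(=O)NC(=O)CCc1cccc(-n2c(C(N)=O)cc3ccccc32)c1` gives 4800 nM in an assay for inhibition of Group 10 secretory phospholipase A2 (Homo sapiens), with stated times of 20 min and 60 min; on this read-out higher numbers stand for weaker inhibition and lower numbers for stronger inhibition.
Compound 2 `NC(=O)c1cc2ccc(C3CC3)cc2n1-c1cccc(CCC(=O)O)c1` gives 160 nM in this assay.

Of these two numbers, compound 2 has the lower one, and compound 1 sits well beyond the scatter above it, so compound 2 is the stronger inhibitor of the pair. The two measured compounds differ in several places at once, so their gap cannot be traced to any single group.

Compound 3 `NC(=O)c1cc2ccc(OCC(F)(F)F)cc2n1-c1cccc(CCC(=O)O)c1` has not yet been measured. It differs from compound 2 in exactly one place: 2,2,2-trifluoroethoxy in place of cyclopropyl on an aromatic carbon. Among the compounds with values here, no measured pair shows what this exchange does, so there is nothing to anchor the expectation beyond compound 2 itself. The expected step is a 1.6-fold higher number from compound 2 to compound 3 (0.19 log units; within the scatter), modest in size and unlikely to reach far beyond the scatter in either direction. Compound 3 is therefore estimated to give 250 nM in this assay, with a range from 80 nM to 800 nM.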

Compound 3, half-maximal inhibitory concentration: 93 nM
Estimate against measurement, compound 3: 2.7-fold (0.43 log units) above; the measured number falls inside the stated range.
By their numbers in this assay, from the lowest: compounds 3 and 2 (each within the scatter of the next); then compound 1.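

In this assay, 2,2,2-trifluoroethoxy in place of cyclopropyl on this aromatic carbon gives a 1.7-fold lower number from compound 2 to compound 3 (0.24 log units; within the scatter), so the two compounds cannot be told apart. Within the data shown here, this is the first look at a change at this position alone, and it shows that the position can hold either a three-membered carbon ring or an open chain with oxygen and fluorine without the number moving beyond the scatter. No measurement available here explains why these two different groups give such similar numbers.

As far as these compounds go, only these two groups can be compared at this position, so it remains open whether an amine or a longer ether chain would fit as well. It is also unclear how much either group contributes compared with a plain hydrogen on the same carbon.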